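The source may report more compounds than this note shows. Statements on the series, on what has been measured and on what is new or still open speak of the compounds shown alone.

In an ADME assay (on this read-out lower numbers stand for a shorter-lived compound and higher numbers for a longer-lived compound), compound 1 `COc1ccc(C[S+]([O-])c2ncccc2C(=O)Nc2ccncc2)c(OC)c1` gives 38.5 h and compound 2 `COc1cc(OC)c(C[S+]([O-])c2ncccc2C(=O)Nc2ccncc2)c(OC)c1` gives 0.29 h as the lower of the two numbers. Going by the values given here, the one measured step is large: a 130-fold lower number from compound 1 to compound 2 (2.12 log units; beyond the scatter) when methoxy takes the place of hydrogen on an aromatic carbon. Compound 3 `COc1cc(C)c(C[S+]([O-])c2ncccc2C(=O)Nc2ccncc2)c(OC)c1` changes that same carbon, which is ortho to a large group and meta to two methoxy groups. There, methyl stands in place of methoxy methyl in place of methoxy on an aromatic carbon on an aromatic carbon. Among the compounds with values here, no measured compound carries methyl on this carbon, so the step of a 130-fold lower number from compound 1 to compound 2 (2.12 log units; beyond the scatter) is the only guide. It points to a rise in this assay that recovers part of that fall, probably beyond the scatter. The estimate therefore means an 8.6-fold higher number from compound 2 to compound 3 (0.94 log units; beyond the scatter) as an expected rise. For compound 3 the expected number is 2.5 h with an estimated range from 0.5 h to 15 h for now.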

Compound 3, half-life: 4.28 h
The estimate for compound 3 lay 1.7-fold (0.23 log units) below the measured number; low and high end bracket the measured number.
By their numbers in this assay, from the lowest: compound 2; then compound 3; then compound 1.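

In this assay, the fall seen on adding methoxy at this carbon does not apply to every group placed there: methyl in place of methoxy gives a 15-fold higher number from compound 2 to compound 3 (1.17 log units; beyond the scatter). A group at this carbon still carries a cost, however, as methyl in place of hydrogen gives a 9.0-fold lower number from compound 1 to compound 3 (0.95 log units; beyond the scatter), so compound 1, with hydrogen there, keeps the highest number of the three, and the identity of the group, not only its presence, sets the outcome. No measurement shown here gives a reason for these differences.

The compounds shown leave open where an amine, a chlorine atom or a longer chain such as ethyl would fall on this carbon relative to hydrogen, methyl and methoxy. They also leave open whether the same order would hold if the two other methoxy groups were changed.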